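The compounds below may be only part of what the source reports. "The series", "measured", "known", "first", "only" and "open" are said of these compounds alone.

Compound 1 `COc1ccc(/C=C/[C@@](C)(/C=C/c2ccc(O)cc2)CCC=C(C)C)cc1`: > 36600 nM
Compound 2 `CC(C)=CCC[C@](C)(/C=C/c1ccc(O)cc1)/C=C/c1cccc(F)c1`: > 36600 nM

Both entries come from an ADME assay on BJ cells (Homo sapiens) for cytotoxicity, with a stated time of 72 h (a lower number here means that less compound is needed, a higher number that more compound is needed for the effect), and neither is a number. Compound 2 gives > 36600 nM, which is a limit of the assay. Compound 1 gives > 36600 nM, which is also a limit. Compound 2 therefore has a position only in relation to that limit, and the limit of > 36600 nM in this assay, at which 2 of the 2 values shown sit, is all that the data show.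

Compound 3 `CC(C)=CCC[C@](C)(/C=C/c1ccc(O)cc1)/C=C/c1cccc(Cl)c1` differs from compound 2 in a single place: chloro in place of fluoro on an aromatic carbon. This is chloro in place of fluoro on an aromatic carbon, meta to a large group.

Among the measured compounds shown here, the only measured step that bears on this change is a step that the two limits leave unreadable from compound 1 to compound 2. It replaces 4-methoxyphenyl with 3-fluorophenyl, and its size cannot be read. It therefore offers no measured size or direction for the new change, and no step beyond the scatter is expected in this assay. Compound 3 is expected to be reported most likely as a limit as well.

The estimated change is a step that the limit leaves unreadable from compound 2 to compound 3. If a number is obtained, compound 3 is estimated at 40000 nM, within an expected range of 20000 nM to 80000 nM.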

Compound 3, half-maximal effective concentration: > 36600 nM
Compound 3 gave a limit, no number (the forecaster's own chance of this, stated with the estimate: 85%); the middle value lies beyond the limit too.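

No step can be read between compound 1, compound 2 and compound 3 in this assay, neither the change from compound 2 to compound 3 nor that from compound 1 to compound 3, and the result is a limit throughout: the limit of > 36600 nM in this assay, at which 3 of the 3 values shown sit.

The compounds shown leave open how far apart these three stand in this assay, and whether any replacement on the shared core would give a number.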